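Triazole amides: ester-to-acetate swap, all at the limit

The source may report more compounds than this note shows. Statements on the series, on what has been measured and on what is new or still open speak of the compounds shown alone.

Three members of this triazole series have been tested, and none yields a number. Compound 1 `CCOC(=O)Cn1cc(CNC(=O)c2cn(CCOC(C)=O)nn2)nn1` is the smallest of them. In a functional assay on B16 cells (Mus musculus) for cytotoxicity, read by MTT assay, with a stated time of 48 h (on this read-out higher numbers stand for weaker inhibition and lower numbers for stronger inhibition), compound 1 gives > 100000 nM, which is a limit of the assay and not a number. Compound 2 `CC(=O)OCCn1cc(CNC(=O)c2cn(CCOC(C)=O)nn2)nn1` differs from it by acetoxymethyl in place of ethoxycarbonyl on a saturated chain carbon bound to an aromatic nitrogen. In this assay compound 2 gives > 100000 nM, again a limit. The step that the two limits leave unreadable from compound 1 to compound 2 therefore cannot be sized. Compound 3 `CCOC(=O)Cn1cc(C(=O)Nc2cccc(-c3cn(CC(=O)OCC)nn3)c2)nn1` carries a different core; how the two cores differ is not broken down here. In this assay compound 3 gives > 100000 nM, also a limit. Across the measured set the one recurring fact is the limit of > 100000 nM in this assay, at which 3 of the 3 values shown sit.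

Compound 4 `CCOC(=O)Cn1cc(C(=O)Nc2cccc(-c3cn(CCOC(C)=O)nn3)c2)nn1` has not yet been measured. It differs from compound 3 by acetoxymethyl in place of ethoxycarbonyl on a saturated chain carbon bound to an aromatic nitrogen, the same change as between compound 1 and compound 2, made at a place described in the same words. Because the earlier instance, a step that the two limits leave unreadable from compound 1 to compound 2, moved nothing that could be read, and because of the limit of > 100000 nM in this assay, at which 3 of the 3 values shown sit, the expected step is a number no higher from compound 3 to compound 4 (the limit leaves the size open), essentially none. Compound 4 is accordingly estimated at 100000 nM in this assay, with an expected range from 50000 nM to 200000 nM, and most likely only a limit will again be reported.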

Compound 4, half-maximal inhibitory concentration: > 100000 nM
Compound 4 gave a limit, no number; the forecaster's own chance of this, stated with the estimate: 85%; the middle value sits exactly at the limit.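

In this assay compound 4 gives > 100000 nM as a limit of the assay and not a number. With compound 3 also at a limit, no step can be read for this pair, and the measured set holds one recurring fact: the limit of > 100000 nM in this assay, at which 4 of the 4 values shown sit.

The compounds shown leave open whether any member of this series reaches a readable value, and whether exchanging ethoxycarbonyl for acetoxymethyl changes that value at all.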